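The source may report more compounds than this note shows. Statements on the series, on what has been measured and on what is new or still open speak of the compounds shown alone.

Compound 1 `Cc1ccc(Cn2cc(CSC(=S)N3CCN(C(=O)OC(C)(C)C)CC3)nn2)cc1` and compound 2 `CC(C)(C)OC(=O)N1CCN(C(=S)SCc2cn(Cc3ccc(Cl)cc3)nn2)CC1` both carry a tert-butoxycarbonyl group on the ring nitrogen; compound 3 `S=C(SCc1cn(Cc2ccc(Cl)cc2)nn1)N1CCNCC1` and compound 4 `Cc1ccc(Cn2cc(CSC(=S)N3CCNCC3)nn2)cc1` do not. In a functional assay on MGC-803 cells (Homo sapiens) for inhibition, read by MTT assay, with a stated time of 72 h (a lower number here means a stronger inhibitor, a higher number a weaker inhibitor), compound 2 gives 9790 nM, while compound 1 gives 3490 nM. The step of a 2.8-fold lower number from compound 2 to compound 1 (0.45 log units; beyond the scatter) arises from methyl in place of chloro on an aromatic carbon. In this assay compound 3 gives "not determined" (no result reported), so no number stands for it. Compound 4 differs from compound 3 by methyl in place of chloro on an aromatic carbon, the same change, made on a core that differs from the core of compound 2 by hydrogen in place of tert-butoxycarbonyl on an amine nitrogen in a ring. A step of similar size is expected from compound 3 to compound 4 in this assay, resting only on a 2.8-fold lower number from compound 2 to compound 1 (0.45 log units; beyond the scatter). Since compound 3 is unmeasured, the expectation for compound 4 leans on compound 1 at 3490 nM. Compound 4 is estimated at 3500 nM, expected between 600 nM and 20000 nM.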

Compound 4, half-maximal inhibitory concentration: 64300 nM
Compound 4: the middle estimate sits 18-fold (1.26 log units) below what was measured; the whole stated range lies below it.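

In this assay, the step of an 18-fold higher number from compound 1 to compound 4 (1.27 log units; beyond the scatter) comes from swapping tert-butoxycarbonyl for hydrogen on the ring nitrogen, so in this pair that swap counts for far more than the methyl-for-chloro step a 2.8-fold lower number from compound 2 to compound 1 (0.45 log units; beyond the scatter) seen on the protected core. As far as these compounds go, compound 3 has no number, so the methyl-for-chloro step cannot be read on the core without tert-butoxycarbonyl, and whether it carries over to that core remains unknown. Nothing shown here gives a measured reason for the large step.

The compounds shown leave open how other groups on that ring nitrogen, such as acetyl or benzyl, would read in this assay. They also leave open whether methoxy in place of methyl on the aromatic ring would change the number on either core.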